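This account rests on a few compounds, and the source may have more. Where it says the series, first, only, none or still open, it means among the compounds named here.

The three measured compounds share one core: compound 1 (`COc1ccc(-c2c[nH]c(=O)n2-c2cc(OC)c(OC)c(OC)c2)cc1OC`), compound 2 (`COc1ccc(-c2c[nH]c(=O)n2-c2cc(OC)c(OC)c(OC)c2)cc1[N+](=O)[O-]`) and compound 3 (`COc1ccc(-c2c[nH]c(=O)n2-c2cc(OC)c(OC)c(OC)c2)cc1N`). In a functional assay on A549 cells (Homo sapiens) for cytotoxicity, read by MTT assay, with a stated time of 48 h (a higher number here means a weaker inhibitor, a lower number a stronger inhibitor), compound 1 gives > 50000 nM, which is a limit of the assay and not a number. In this assay compound 2 gives > 50000 nM, also a limit. Compound 3 gives > 50000 nM, again a limit. All three therefore sit at the same point: the limit of > 50000 nM in this assay, at which 3 of the 3 values shown sit. No actual potency can be read for compound 2.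

Compound 4 (`COc1ccc(-c2cn(C(C)=O)c(=O)n2-c2cc(OC)c(OC)c(OC)c2)cc1[N+](=O)[O-]`) differs from compound 2 by one change: acetyl in place of hydrogen on an aromatic nitrogen. In words, this is acetyl in place of hydrogen on an aromatic nitrogen.

The measured steps involve changes on an aromatic carbon instead, and none has a readable size: a step that the two limits leave unreadable from compound 1 to compound 2, a step that the two limits leave unreadable from compound 1 to compound 3 and a step that the two limits leave unreadable from compound 2 to compound 3. They offer no measure of what an acetyl does here, so the expectation is loose. The expected change is an at least 1.2-fold lower number from compound 2 to compound 4 (0.09 log units; that floor lies within the scatter), a modest shift towards stronger inhibition, if any. For compound 4 the estimated value is 40000 nM, with an expected range from 2000 nM to 100000 nM.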

Compound 4, half-maximal inhibitory concentration: 40900 nM
Compound 4: middle estimate off by 1.0-fold (0.01 log units), on the low side; low and high end bracket the measured number.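

Acetyl on the aromatic nitrogen gives the first value in this series that is not a limit: in this assay compound 4 gives 40900 nM. Going by these compounds, the change at this nitrogen amounts to an at least 1.2-fold lower number from compound 2 to compound 4 (0.08 log units; that floor lies within the scatter), so unlike the steps on the aromatic carbon, which cannot be read, this one has a floor, though its true size stays unknown and that floor does not establish a real gain in inhibition. The other three values remain at one point: the limit of > 50000 nM in this assay, at which 3 of the 4 values shown sit.

On these data alone, it remains open whether acetyl is special at this nitrogen or whether a methyl or a benzoyl group there would give a similar number. As far as these compounds go, it is also open whether acetyl on the same nitrogen of compound 1 or compound 3 would give a value that is not a limit.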